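Methyl in Place of Fluoro on a Core at the Limit

A few compounds are considered here, and "the series" means these few. Any claim that something is new, unique, unknown or untested is made for them only; others in the source may bear on it.

Compound 1, `O=C1c2cccc(F)c2C(=O)C1(O)O`, was tested in an assay on isolated protein for inhibition of carbonic anhydrase 4 (Homo sapiens), read by stopped-flow, with a stated time of 15 min; a higher number here means a weaker inhibitor, a lower number a stronger inhibitor. In this assay compound 1 gives > 100000 nM, which is a limit of the assay and not a number. Compound 2, `CC(C)Oc1cccc2c1C(=O)C(O)(O)C2=O`, gives > 100000 nM, also a limit. Compound 3, `COc1cccc2c1C(=O)C(O)(O)C2=O`, gives > 100000 nM, again a limit. Because of the limit of > 100000 nM in this assay, at which 3 of the 3 values shown sit, the steps a step that the two limits leave unreadable from compound 1 to compound 2, a step that the two limits leave unreadable from compound 1 to compound 3 and a step that the two limits leave unreadable from compound 2 to compound 3 cannot be sized. Compound 4, `Cc1cccc2c1C(=O)C(O)(O)C2=O`, differs from compound 1 by methyl in place of fluoro on an aromatic carbon. Among the compounds with values here, no measured step bears on this change, so no step beyond the scatter is expected, and most likely another limit. Compound 4 is therefore estimated at 150000 nM, with a range from 50000 nM to 500000 nM. This estimate is expected to mean a step that the limit leaves unreadable from compound 1 to compound 4 in this assay.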

Compound 4, inhibition constant: > 100000 nM
Compound 4: no number, only a limit (the forecaster's own chance of this, stated with the estimate: 85%); the middle value lies beyond the limit too.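

Compound 4 sits at a limit of the assay, as do compound 1, compound 2 and compound 3, so no step between them can be read: the limit of > 100000 nM in this assay, at which 4 of the 4 values shown sit.

The compounds shown leave open whether fluoro, methyl, methoxy or isopropoxy on the shared core makes any difference in this assay.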